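The source may report more compounds than this note shows. Statements on the series, on what has been measured and on what is new or still open speak of the compounds shown alone.

Compound 1: `CCCCC(=O)OCCc1c(-c2ccccc2Cl)c2cc(Cl)ccc2[nH]c1=O`, 200000 nM
Compound 2: `O=C(OCCc1c(-c2ccccc2Cl)c2cc(Cl)ccc2[nH]c1=O)c1ccco1`, 98000 nM

Both esters of the shared core have been tested in an ADME assay on HepG2 2.2.15 cells (Homo sapiens) for cytotoxicity; on this read-out higher numbers stand for lower toxicity in this test and lower numbers for higher toxicity in this test. Among the measured compounds shown here, on these two numbers compound 2 stands lowest, and its only neighbour is compound 1; the single measured step between them is a 2.0-fold lower number from compound 1 to compound 2 (0.31 log units; beyond the scatter), a modest move that does lie beyond the scatter. Compound 3, `C/C=C/C(=O)OCCc1c(-c2ccccc2Cl)c2cc(Cl)ccc2[nH]c1=O`, differs from compound 2 by prop-1-en-1-yl in place of furan-2-yl on a carbonyl carbon. For the measured compounds named here, no measured step covers a prop-1-en-1-yl group on this carbonyl carbon, so the expectation rests on the one step known: the move from a butyl chain to furan-2-yl lowered the number, and the change to compound 3 takes the ester back to a chain, one that is shorter and holds a double bond. The number for compound 3 is therefore expected to move back toward that of compound 1 by a modest amount, or to stay within the scatter of compound 2. For compound 3 the estimate in this assay is 150000 nM, with a range from 60000 nM to 400000 nM, which corresponds to an expected step of a 1.5-fold higher number from compound 2 to compound 3 (0.18 log units; within the scatter).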

Compound 3, half-maximal cytotoxic concentration: 30000 nM
Compound 3: the middle estimate sits 5.0-fold (0.70 log units) above what was measured, and the stated range ends above it.
By their numbers in this assay, from the lowest: compound 3; then compound 2; then compound 1.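

On the carbonyl carbon of this ester, the chain itself matters in this assay: prop-1-en-1-yl in place of furan-2-yl gives a 3.3-fold lower number from compound 2 to compound 3 (0.51 log units; beyond the scatter), and prop-1-en-1-yl in place of butyl gives a 6.7-fold lower number from compound 1 to compound 3 (0.82 log units; beyond the scatter). A return from the ring to a chain therefore does not by itself bring the number back, as the two chain esters now stand at opposite ends of the series, with the furan-2-yl ester of compound 2 lying between them, and the earlier step, a 2.0-fold lower number from compound 1 to compound 2 (0.31 log units; beyond the scatter), no longer marks the low end of what this position can give. The data shown hold nothing that explains this ordering of the three esters.

The compounds shown leave open whether the lower number of compound 3 goes with the double bond or with the shorter chain, a question that a saturated propyl group on the same carbonyl carbon would address. They also leave open how the number would respond to a longer chain or to an amine at this place, and whether the same order of esters would hold on a core other than the shared one.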